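The source may hold more compounds than are shown below. What is called first, only, known or untested is meant among the compounds shown, and "the series" means these compounds.

Measured in a functional assay on SGC-7901 cells (Homo sapiens) for antiproliferative activity, read by MTT assay, with a stated time of 72 h; a higher number here means a weaker inhibitor, a lower number a stronger inhibitor:
- Compound 1 `COc1ccc(-c2sccc2-c2cc(OC)c(OC)c(OC)c2)cc1`: 5470 nM
- Compound 2 `CCOC(=O)c1cc(-c2ccc(OC)cc2)c(-c2cc(OC)c(OC)c(OC)c2)s1`: 6820 nM

Among the measured compounds shown here, these are the only two numbers so far, and they tell little apart. Compound 2 at 6820 nM lies within the usual scatter of compound 1 at 5470 nM, so neither can be ranked over the other.

The next compound, compound 3 `CCOC(=O)c1cc(-c2ccc(OC)c(O)c2)c(-c2cc(OC)c(OC)c(OC)c2)s1`, keeps everything in compound 2 except for one place: hydroxy in place of hydrogen on an aromatic carbon. A hydroxy takes the place of a hydrogen on an aromatic carbon, so the 4-methoxyphenyl becomes 3-hydroxy-4-methoxyphenyl.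

For the measured compounds named here, no measured pair shows this change, so any forecast is a judgement with wide margins. With compound 2 at 6820 nM, there is plenty of room for the number to fall, and a stronger inhibitor seems likelier than a weaker one. The expected change is a 7.6-fold lower number from compound 2 to compound 3 (0.88 log units; beyond the scatter), a move towards a lower number that should exceed the scatter, though no change at all cannot be ruled out. In this assay, compound 3 is estimated at 900 nM, with an expected range of 60 nM to 7000 nM.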

Compound 3, half-maximal inhibitory concentration: 20000 nM
Estimate against measurement, compound 3: 22-fold (1.35 log units) below; the measured number lies above the stated range.
By their numbers in this assay, from the lowest: compounds 1 and 2 (each within the scatter of the next); then compound 3.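

In this assay, putting a hydroxy in place of hydrogen on the aromatic carbon ortho to the methoxy group, which turns 4-methoxyphenyl into 3-hydroxy-4-methoxyphenyl, gives a 2.9-fold higher number from compound 2 to compound 3 (0.47 log units; beyond the scatter) for this one change. Among the compounds shown here, this is the only step so far that lies beyond the scatter, and it shows that this position on the ring is not indifferent to what stands on it: here, the added hydroxy gives a weaker inhibitor, although the step is modest. Nothing on hand explains the rise in the number, so it stands as an observation only.

The compounds shown leave open whether any group at this position would weaken the inhibitor or whether the effect belongs to the hydroxy alone, and a fluorine, an amine or a second methoxy at the same place would help to tell these apart. Also open, from the compounds shown here alone, is whether the same hydroxy would move the number the same way on the core of compound 1, as this step is read on a single background, the one carrying the ethyl ester.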